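From Methoxy to Methyl on an Aromatic Carbon

The source may report more compounds than this note shows. Statements on the series, on what has been measured and on what is new or still open speak of the compounds shown alone.

Measured so far in an ADME assay on SH-SY5Y cells (Homo sapiens) for cytotoxicity, read by MTT assay, with a stated time of 72 h; on this read-out lower numbers stand for stronger inhibition and higher numbers for weaker inhibition
Compound 1 `COc1ccc2[nH]cc(CCCN3CCN(C(=O)CN4CCN(C(=O)c5ccc(Cl)cc5)CC4)CC3)c2c1` gives 159000 nM
Compound 2 `COc1ccc(C(=O)N2CCN(CC(=O)N3CCN(CCCc4c[nH]c5ccc(OC)cc45)CC3)CC2)cc1` gives 190000 nM

Only these two numbers are available. Going by the values given here, compound 2 (190000 nM) stands within the scatter of its single neighbour, compound 1 (159000 nM), so the two cannot be told apart.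

The next compound to be measured is compound 3 `COc1ccc2[nH]cc(CCCN3CCN(C(=O)CN4CCN(C(=O)c5ccc(C)cc5)CC4)CC3)c2c1`, which carries methyl in place of methoxy on an aromatic carbon, para to a large group (methyl in place of methoxy on an aromatic carbon). In other words, 4-methoxyphenyl becomes 4-methylphenyl, and the rest of compound 2 stays as it is.

Among the compounds with values here, one measured step bears on this change, the exchange of chloro for methoxy on an aromatic carbon (a 1.2-fold higher number from compound 1 to compound 2 (0.08 log units; within the scatter)), and it stayed within the scatter. No measured step involves methyl itself, so this is thin evidence, but it gives no reason to expect a real shift in either direction in this assay. The expected change is no larger than the scatter (a 1.1-fold lower number from compound 2 to compound 3 (0.05 log units; within the scatter)). For compound 3 the expected value is 170000 nM (estimated range 100000 nM to 290000 nM).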

Compound 3, half-maximal inhibitory concentration: > 200000 nM
Compound 3 gave a limit, no number (the forecaster's own chance of this, stated with the estimate: 10%); middle value at least 1.1-fold (0.07 log units) from the limit.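

In this assay compound 3 gives > 200000 nM, which is a limit of the assay and not a number. Methyl on this aromatic carbon, para to a large group, adds a third group to chloro and methoxy, and the two new steps, an at least 1.0-fold higher number from compound 2 to compound 3 (0.02 log units; that floor lies within the scatter) and an at least 1.2-fold higher number from compound 1 to compound 3 (0.09 log units; that floor lies within the scatter), give only floors, so methyl cannot be told apart from either group, while its true distance from them stays unknown. Unlike the earlier pair, which had two numbers and a closed step, this change is open at one end, and the series now reaches the ceiling of the read-out: the limit of > 200000 nM in this assay, at which 1 of the 3 values shown sits.

The compounds shown leave open whether any group at this position can bring the number down beyond the scatter, for instance an amine or a carboxylic acid on the same aromatic carbon. Going by these compounds alone, they also leave open how much the rest of the structure matters, such as a longer chain in place of the one joining the shared core to the first piperazine-bearing part, since all three compounds differ only in the one group.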